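Removing one methoxy from the cinnamoyl ring of compound 3

The source may report more compounds than this note shows. Statements on the series, on what has been measured and on what is new or still open speak of the compounds shown alone.

Three cytotoxic compounds have been measured in a functional assay on DU-145 cells (Homo sapiens) for cytotoxicity, read by MTT assay, with a stated time of 72 h; a higher number here means a weaker inhibitor, a lower number a stronger inhibitor. Compound 1 `COc1cccc(/C=C/C(=O)Nc2cc(C(=O)c3cc(OC)c(OC)c(OC)c3)ccc2OC)c1` gives 6200 nM. Compound 2 `COc1cc(C(=O)c2cc(OC)c(OC)c(OC)c2)cc(NC(=O)/C=C/c2cc(OC)c(OC)c(OC)c2)c1OC` gives 6600 nM. Compound 3 `COc1ccc(/C=C/C(=O)Nc2cc(C(=O)c3cc(OC)c(OC)c(OC)c3)cc(OC)c2OC)cc1OC` gives 7800 nM, the highest of the three numbers, although the gaps to compound 2 and to compound 1 both lie within the scatter, so the three read as equivalent. Compound 4 `COc1cccc(/C=C/C(=O)Nc2cc(C(=O)c3cc(OC)c(OC)c(OC)c3)cc(OC)c2OC)c1` differs from compound 3 by hydrogen in place of methoxy on an aromatic carbon. Going by the values given here, only one measured step is of the same kind, a methoxy replaced by hydrogen on an aromatic carbon, though on the other ring: a 1.2-fold higher number from compound 2 to compound 3 (0.07 log units; within the scatter). Compound 1, which carries the same 3-methoxyphenyl group as compound 4 but a different second ring, gives a value close to compound 3. Nothing here points to a shift beyond the scatter, so compound 4 is expected to sit near compound 3, with a 1.1-fold lower number from compound 3 to compound 4 (0.05 log units; within the scatter). The estimate for compound 4 in this assay is 7000 nM, with a range from 3500 nM to 14000 nM.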

Compound 4, half-maximal inhibitory concentration: 12500 nM
Estimate against measurement, compound 4: 1.8-fold (0.25 log units) below, and the stated range covers the measured number.
By their numbers in this assay, from the lowest: compounds 1, 2, 3 and 4 (each within the scatter of the next).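

Going from the 3,4-dimethoxyphenyl group to the 3-methoxyphenyl group gives a 1.6-fold higher number from compound 3 to compound 4 (0.20 log units; within the scatter), so in this assay this methoxy can be replaced by hydrogen without a step beyond the scatter. Cutting the 3,4,5-trimethoxyphenyl group down to 3-methoxyphenyl in a single step also stays within the scatter, with a 1.9-fold higher number from compound 2 to compound 4 (0.28 log units; within the scatter), and so does adding a methoxy on the other ring, with a 2.0-fold higher number from compound 1 to compound 4 (0.30 log units; within the scatter). The swap of methoxy for hydrogen can now be compared on two cores, and the two results do not differ beyond the scatter: the same change on two cores in this assay, a 1.2-fold higher number (0.07 log units; within the scatter) from compound 2 to compound 3 and a 2.0-fold lower number (0.30 log units; within the scatter) from compound 4 to compound 1, 2.4-fold (0.38 log units) apart, within the scatter of two such steps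

The compounds shown carry only methoxy or hydrogen at this position, so it remains open whether a hydroxyl group, a chlorine or an amine there would shift the number beyond the scatter. As far as these compounds go, whether the same holds in other cells is also open, as every value here comes from this assay.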